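A few compounds are considered here, and "the series" means these few. Any claim that something is new, unique, unknown or untested is made for them only; others in the source may bear on it.

Going by the values given here, compound 3 `CCS(=O)(=O)Nc1ccc(C(C)C(=O)NCc2ccc(C(F)(F)F)nc2N2CCC(C)CC2)cc1F` gives 4.4 nM in an assay on cells for antagonist activity at transient receptor potential cation channel subfamily V member 1 (Homo sapiens), read by FLIPR and calcium flux, with a stated time of 15 min (a lower number here means a stronger inhibitor, a higher number a weaker inhibitor), the highest of the three numbers measured so far: compound 1 `CC1CCN(c2nc(C(F)(F)F)ccc2CNC(=O)C(C)c2ccc(NS(C)(=O)=O)cc2)CC1` gives 1.2 nM and compound 2 `CC1CCN(c2nc(C(F)(F)F)ccc2CNC(=O)C(C)c2ccc(NS(C)(=O)=O)c(Br)c2)CC1` gives 3.2 nM, so compound 3 lies beyond the scatter from compound 1 but within it of compound 2. Compound 4 `C=CC(=O)N(c1ccc(C(C)C(=O)NCc2ccc(C(F)(F)F)nc2N2CCC(C)CC2)cc1F)S(C)(=O)=O` differs from compound 3 by (methylsulfonyl)(vinylcarbonyl)amino in place of (ethylsulfonyl)amino on an aromatic carbon. Among the compounds with values here, the only measured step, a 2.7-fold higher number from compound 1 to compound 2 (0.43 log units; beyond the scatter), is a different kind of change and bears on this one only loosely. Within the data shown here, with no step of this kind measured, a shift toward weaker inhibition is expected for compound 4, a 6.8-fold higher number from compound 3 to compound 4 (0.83 log units; beyond the scatter). Compound 4 is therefore estimated at 30 nM, somewhere between 5 nM and 200 nM.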

Compound 4, inhibition constant: 2.4 nM
Beside the measured number, compound 4's estimate is 13-fold (1.10 log units) above it, outside the stated range (below it).
By their numbers in this assay, from the lowest: compounds 1, 4, 2 and 3 (each within the scatter of the next, the first and the last beyond it).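

At this position on the aromatic ring, a larger group with no hydrogen-bond donor, (methylsulfonyl)(vinylcarbonyl)amino, takes the place of (ethylsulfonyl)amino and gives a 1.8-fold lower number from compound 3 to compound 4 (0.26 log units; within the scatter) so the two compounds cannot be told apart in this measurement. The earlier compounds shown here showed only a change on another ring carbon, not a change to this nitrogen group itself. Nothing measured here explains why the number holds.

From the compounds shown here alone, two things change at once, the ethyl becoming methyl and the vinylcarbonyl being added, so their separate contributions stay unknown. Also open, going by these compounds, is whether a saturated propanoyl group in place of the vinylcarbonyl would give a similar number.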